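The source may report more compounds than this note shows. Statements on the series, on what has been measured and on what is new or still open speak of the compounds shown alone.

Compound 1 `COc1cccc(C(=O)N2CCN(CC(=O)N3CCN(CCCc4c[nH]c5ccccc45)CC3)CC2)c1` gives 143000 nM in an ADME assay on HEK293 cells (Homo sapiens) for cytotoxicity, read by MTT assay, with a stated time of 72 h; a lower number here means a stronger inhibitor, a higher number a weaker inhibitor. Compound 2 `O=C(CN1CCN(C(=O)c2cccc(Br)c2)CC1)N1CCN(CCCc2c[nH]c3ccccc23)CC1` gives 80700 nM in this assay, and compound 3 `COc1cccc(C(=O)N2CCN(CC(=O)N3CCN(CCCc4c[nH]c5ccc(F)cc45)CC3)CC2)c1` gives 87100 nM there. The change from compound 1 to compound 2, (bromo in place of methoxy on an aromatic carbon), made a step of a 1.8-fold lower number from compound 1 to compound 2 (0.25 log units; within the scatter). The two cores differ by fluoro in place of hydrogen on an aromatic carbon, and that step reads a 1.6-fold lower number from compound 1 to compound 3 (0.22 log units; within the scatter). Compound 4 `O=C(CN1CCN(C(=O)c2cccc(Br)c2)CC1)N1CCN(CCCc2c[nH]c3ccc(F)cc23)CC1` has not yet been measured. It differs from compound 3 by bromo in place of methoxy on an aromatic carbon, the same change as between compound 1 and compound 2, at a place described in the same words. Because the step of a 1.8-fold lower number from compound 1 to compound 2 (0.25 log units; within the scatter) stayed within the scatter, a step of about a 1.6-fold lower number from compound 3 to compound 4 (0.20 log units; within the scatter) is expected from compound 3 to compound 4 in this assay. Compound 4 is therefore estimated at 55000 nM, between 25000 nM and 120000 nM.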

Compound 4, half-maximal inhibitory concentration: 40600 nM
For compound 4 the middle estimate is 1.4-fold (0.13 log units) above the measured one; the range from low to high includes it.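

In this assay, bromo in place of methoxy on an aromatic carbon gave a 2.1-fold lower number from compound 3 to compound 4 (0.33 log units; beyond the scatter), which agrees with the same change on the core of compound 1: the same change on two cores in this assay, a 1.8-fold lower number (0.25 log units; within the scatter) from compound 1 to compound 2 and a 2.1-fold lower number (0.33 log units; beyond the scatter) from compound 3 to compound 4, 1.2-fold (0.08 log units) apart, within the scatter of two such steps. Fluoro in place of hydrogen on an aromatic carbon gave a 2.0-fold lower number from compound 2 to compound 4 (0.30 log units; within the scatter), and this change also carried across: the same change on two cores in this assay, a 1.6-fold lower number (0.22 log units; within the scatter) from compound 1 to compound 3 and a 2.0-fold lower number (0.30 log units; within the scatter) from compound 2 to compound 4, 1.2-fold (0.08 log units) apart, within the scatter of two such steps. Each change therefore carried from one core to the other in this assay, but each comparison rests on a single pair of steps and does not show that either change would carry to other cores in the series.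

The compounds shown leave open whether a nitrile, an amine or a longer alkoxy chain in place of bromo would behave in the same way on both cores.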